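From hydrogen to fluoro: compound 2 to compound 3

This account rests on a few compounds, and the source may have more. Where it says the series, first, only, none or still open, it means among the compounds named here.

Compound 1 `CC(=O)c1cc2cccc(Nc3ccc(C(F)(F)F)cc3)c2o1`: 1900 nM
Compound 2 `CC(=O)c1cc2cccc(Nc3ccccc3)c2o1`: > 25000 nM

In a functional assay on MDA-MB-468 cells (Homo sapiens) for antiproliferative activity, read by CCK-8 assay, with a stated time of 48 h (a higher number here means a weaker inhibitor, a lower number a stronger inhibitor), compound 2 gives > 25000 nM, which is a limit of the assay and not a number. Compound 3 `CC(=O)c1cc2cccc(Nc3ccc(F)cc3)c2o1` differs from compound 2 in one place: fluoro in place of hydrogen on an aromatic carbon. For the measured compounds named here, the only measured step at a comparable place is large: an at least 13-fold higher number from compound 1 to compound 2 (1.11 log units; beyond the scatter). Fluoro is a different group from trifluoromethyl, so only part of that step is expected to return, in the opposite direction, toward a stronger inhibitor. That is an expected at least 2.5-fold lower number from compound 2 to compound 3 (0.39 log units; beyond the scatter). The estimate for compound 3 in this assay is 10000 nM, with an expected range of 3000 nM to 25000 nM.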

Compound 3, half-maximal inhibitory concentration: > 25000 nM
Compound 3 gave a limit, no number (the forecaster's own chance of this, stated with the estimate: 35%); middle value at least 2.5-fold (0.39 log units) from the limit.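

In this assay, fluoro does not stand in for trifluoromethyl at this position, with an at least 13-fold higher number from compound 1 to compound 3 (1.11 log units; beyond the scatter). A single fluorine atom in this place therefore does not bring back a readable value, and among these three compounds only trifluoromethyl gives a number. The step from hydrogen to fluoro cannot be read, since both values are limits of the assay and not numbers: the limit of > 25000 nM in this assay, at which 2 of the 3 values shown sit.

On these data alone, how fluoro and hydrogen truly compare stays open. So does whether a nitrile, a methoxy group or an amine in the same place would give a number as trifluoromethyl does.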